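Replacing a Fluoro Partner with a Dichloro One

This account rests on a few compounds, and the source may have more. Where it says the series, first, only, none or still open, it means among the compounds named here.

Compound 3 `COc1cc(C(=O)N/N=C/c2ccc(F)cc2)cc(OC)c1OC` gives the strongest effect of the three compounds measured in a functional assay on PC-3 cells (Homo sapiens) for antiproliferative activity, read by MTT assay, tested at 5 uM (a lower number here means a weaker effect, a higher number a stronger effect of the compound at the concentration tested), with compound 3 at 82.8%. Its nearest neighbour, compound 1 `COc1cc(C(=O)N/N=C/c2ccc(C(F)(F)F)cc2)cc(OC)c1OC`, gives 61.6%, and compound 2 `COc1ccc(OC)c(/C=N/NC(=O)c2cc(OC)c(OC)c(OC)c2)c1` gives 51.7%; both gaps lie beyond the scatter. Among the measured compounds shown here, the only measured step that changes a single group, a number 21.2 percentage points higher from compound 1 to compound 3 (beyond the scatter), shows that exchanging one halogen-bearing group for another can shift the number substantially. Compound 4 `COc1cc(C(=O)N/N=C/c2cc(Cl)cc(Cl)c2)cc(OC)c1OC` differs from compound 3 by 3,5-dichlorophenyl in place of 4-fluorophenyl on a carbon with a double bond to nitrogen. For the measured compounds named here, no measured pair mirrors this exact exchange, so the data only show that such swaps can matter, and a modest decrease is expected. For compound 4 the estimated value in this assay is 65%, ranging from 45% to 85%, an expected step of a number 17.8 percentage points lower from compound 3 to compound 4 (beyond the scatter).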

Compound 4, a percentage reported as inhibition, at one concentration (the size of the read-out at that concentration, not a potency): 46.3%
Compound 4: middle estimate off by 18.7 percentage points, on the high side; the measured number falls inside the stated range.
By their numbers in this assay, from the lowest: compounds 4, 2 and 1 (each within the scatter of the next, the first and the last beyond it); then compound 3.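

In this assay, moving from 4-fluorophenyl to 3,5-dichlorophenyl on this carbon gives a number 36.5 percentage points lower from compound 3 to compound 4 (beyond the scatter), so this place on the molecule responds strongly to the halogen pattern on the ring, and not every halogen-bearing ring keeps the number high. The exchange alters both the kind of halogen and how many there are, and this single step cannot separate the two. Nothing available explains the drop.

On these data alone, it remains open whether a ring with a single chlorine would stay close to compound 3. The same applies to a ring carrying an amine or a carboxylic acid in place of halogen.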